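Aryl Groups on the Saturated Ring Carbon

A few compounds are considered here, and "the series" means these few. Any claim that something is new, unique, unknown or untested is made for them only; others in the source may bear on it.

Measured compounds:
Compound 1 `CC(C)C1C(=O)N(C)c2cnc(Nc3ccc(S(N)(=O)=O)cc3)nc2N1C` gives 254 nM
Compound 2 `CN1C(=O)C(c2ccc(F)cc2)N(C)c2nc(Nc3ccc(S(N)(=O)=O)cc3)ncc21` gives 1770 nM
Compound 3 `CN1C(=O)C(c2cccc(Cl)c2)N(C)c2nc(Nc3ccc(S(N)(=O)=O)cc3)ncc21` gives 989 nM

All three were tested in an assay on Sf9 cells for inhibition of serine/threonine-protein kinase 4 (Homo sapiens), read by luminescence and ADP-Glo, with a stated time of 1 h, in the presence of a further agent that is not named here; on this read-out higher numbers stand for weaker inhibition and lower numbers for stronger inhibition. Compound 3 holds the second highest number of the three. Its nearest neighbour is compound 2, and the step of a 1.8-fold lower number from compound 2 to compound 3 (0.25 log units; within the scatter), so these two cannot be told apart. Its furthest neighbour is compound 1, and the step of a 3.9-fold higher number from compound 1 to compound 3 (0.59 log units; beyond the scatter), a real difference.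

Compound 4 `Cc1ccc(F)cc1C1C(=O)N(C)c2cnc(Nc3ccc(S(N)(=O)=O)cc3)nc2N1C` is not yet measured. It differs from compound 3 by 5-fluoro-2-methylphenyl in place of 3-chlorophenyl on a saturated ring carbon.

Among the compounds with values here, two measured steps bear on this. The step of a 7.0-fold higher number from compound 1 to compound 2 (0.84 log units; beyond the scatter) and the step of a 3.9-fold higher number from compound 1 to compound 3 (0.59 log units; beyond the scatter) both show that an aromatic ring in this position gives a weaker inhibitor than the isopropyl group of compound 1. Between the two aromatic rings themselves, the step of a 1.8-fold lower number from compound 2 to compound 3 (0.25 log units; within the scatter) is within the scatter, so swapping one substituted phenyl for another has so far changed little. Compound 4 keeps an aromatic ring here, so a step within the scatter, or a slightly higher number, is expected in this assay.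

Compound 4 is therefore estimated at 1500 nM, with a likely range from 600 nM to 4000 nM. The expected step is a 1.5-fold higher number from compound 3 to compound 4 (0.18 log units; within the scatter).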

Compound 4, half-maximal inhibitory concentration: 168 nM
Beside the measured number, compound 4's estimate is 8.9-fold (0.95 log units) above it, and the stated range ends above it.
By their numbers in this assay, from the lowest: compounds 4 and 1 (each within the scatter of the next); then compounds 3 and 2 (each within the scatter of the next).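

In this assay, an aromatic ring on this saturated ring carbon need not weaken inhibition: 5-fluoro-2-methylphenyl gives a 5.9-fold lower number from compound 3 to compound 4 (0.77 log units; beyond the scatter) and an 11-fold lower number from compound 2 to compound 4 (1.02 log units; beyond the scatter), steps that are both beyond the scatter. Compounds 2 and 3 could not be told apart, so the position had seemed to care little about which substituted phenyl it carried, but compound 4 shows that the pattern of groups on the ring can matter a great deal. The isopropyl group also loses its apparent advantage, since a 1.5-fold lower number from compound 1 to compound 4 (0.18 log units; within the scatter) leaves compound 1 and compound 4 indistinguishable, so the earlier result that an aromatic ring here does worse than isopropyl holds for compounds 2 and 3 but not for compound 4.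

No supporting evidence is available to explain why this ring behaves differently from the other two. The compounds shown also do not separate the methyl group from the fluorine, so it remains open how a phenyl ring carrying only one of them, a plain phenyl ring, or a ring bearing an amine or a carboxylic acid would fare at this position.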